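The source may hold more compounds than are shown below. What is called first, only, known or untested is meant among the compounds shown, and "the series" means these compounds.

Two close analogues of one amide set the stage. Compound 1 `Cn1cc(-c2cnc(N)c(Oc3ccc(C(=O)Nc4cccc(Cl)n4)cc3)n2)cn1` carries a 6-chloropyridin-2-yl group on the amide nitrogen, and in a functional assay on U-87MG ATCC cells for inhibition, with U-87 MG (Homo sapiens) as the target, read by MTT assay, with a stated time of 72 h (a lower number here means a stronger inhibitor, a higher number a weaker inhibitor), compound 1 gives 54800 nM. Compound 2 `Cn1cc(-c2cnc(N)c(Oc3ccc(C(=O)Nc4ccc(Cl)cn4)cc3)n2)cn1` carries a 5-chloropyridin-2-yl group in the same place, and in this assay compound 2 gives 22200 nM; this is the lowest of the two numbers, and the step of a 2.5-fold lower number from compound 1 to compound 2 (0.39 log units; beyond the scatter) is modest. Compound 3 `Cn1cc(-c2cnc(N)c(Oc3ccc(C(=O)Nc4cc(Cl)ccn4)cc3)n2)cn1` is not yet measured; it differs from compound 2 in one place, (4-chloropyridin-2-yl in place of 5-chloropyridin-2-yl on an amide-type nitrogen). Among the measured compounds shown here, only the single step from compound 1 to compound 2 bears on this change, and it shows that moving the chlorine around the pyridine ring shifts the number by a modest amount. A shift of similar size or none beyond the scatter is therefore expected for a 1.1-fold higher number from compound 2 to compound 3 (0.05 log units; within the scatter). Compound 3 is expected to come in at 25000 nM, within the range 8000 nM to 80000 nM.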

Compound 3, half-maximal inhibitory concentration: 47900 nM
Estimate against measurement, compound 3: 1.9-fold (0.28 log units) below; the range from low to high includes it.
By their numbers in this assay, from the lowest: compound 2; then compounds 3 and 1 (each within the scatter of the next).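

In this assay, moving the chlorine now gives three points instead of one step: a 2.2-fold higher number from compound 2 to compound 3 (0.33 log units; beyond the scatter) shows that the 4-chloropyridin-2-yl group does not match the 5-chloropyridin-2-yl group, while a 1.1-fold lower number from compound 1 to compound 3 (0.06 log units; within the scatter) leaves the 4-chloropyridin-2-yl and 6-chloropyridin-2-yl groups indistinguishable. Among these three compounds, which have the same atoms joined differently, only the 5-chloropyridin-2-yl group stands apart, and the effect of moving the chlorine is modest at most. No supporting data are available to explain why this one placement differs.

The compounds shown leave open whether the chlorine itself matters or only its place on the ring. A plain pyridin-2-yl group or a 5-methoxypyridin-2-yl group on the same amide nitrogen would speak to that question.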